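The source may hold more compounds than are shown below. What is called first, only, known or untested is meant among the compounds shown, and "the series" means these compounds.

Compound 1 `COc1cc(/C=C/C(=O)c2cccc(-n3cc(-c4ccccc4)[nH]c3=O)c2)ccc1O`: 1950 nM
Compound 2 `O=C(/C=C/c1cccc(O)c1)c1cccc(-n2cc(-c3ccc(Cl)cc3)[nH]c2=O)c1`: 2410 nM
Compound 3 `COc1cc(/C=C/C(=O)c2cccc(-n3cc(-c4ccccc4)[nH]c3=O)c2)cc(OC)c1OC`: 1400 nM

These three compounds were tested in a functional assay on NCI-H460 cells (Homo sapiens) for inhibition (a higher number here means a weaker inhibitor of growth, a lower number a stronger inhibitor of growth), where compound 1 gives 1950 nM, compound 2 gives 2410 nM and compound 3 gives 1400 nM. Compound 3 has the lowest of the three numbers, but its gaps to compound 1 and to compound 2 both lie within the usual scatter, so no order among them can be claimed.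

Compound 4 `COc1cc(/C=C/C(=O)c2cccc(-n3cc(-c4cc(OC)c(OC)c(OC)c4)[nH]c3=O)c2)cc(OC)c1OC` has not yet been measured. It differs from compound 3 by 3,4,5-trimethoxyphenyl in place of phenyl on an aromatic carbon. Going by the values given here, no measured pair shows the effect of this change, so the step is estimated with little support. The account expects the step from compound 3 to compound 4 in this assay to be a 1.2-fold lower number from compound 3 to compound 4 (0.07 log units; within the scatter), not clearly beyond the scatter. Compound 4 is therefore estimated at 1200 nM, within a range from 400 nM to 3500 nM.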

Compound 4, concentration for 50% growth inhibition: 1730 nM
Compound 4: the middle estimate sits 1.4-fold (0.16 log units) below what was measured; measured number inside the range.
By their numbers in this assay, from the lowest: compounds 3, 4, 1 and 2 (each within the scatter of the next).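

In this assay, going by these compounds alone, the first pair that differs only at this aromatic carbon gives a 1.2-fold higher number from compound 3 to compound 4 (0.09 log units; within the scatter) and so stays within the scatter. The position thus carries 3,4,5-trimethoxyphenyl in place of phenyl, with its larger count of heavy atoms and its three added hydrogen-bond acceptors, without a change that can be read. No measurement shown here offers an explanation for this result. Still open, going by these compounds, is whether a group such as an amine or a carboxylic acid on this phenyl would move the number beyond the scatter.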